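The source may report more compounds than this note shows. Statements on the series, on what has been measured and on what is new or still open speak of the compounds shown alone.

Measured so far:
compound 1 `Cc1cccc(-c2nc(C(C)NC(=O)c3cc(C(F)(F)F)nn3C)no2)c1` — 977 nM
compound 2 `C[C@H](NC(=O)c1cc(C(F)(F)F)nn1C)c1nc(-c2ccccn2)no1` — > 30000 nM

In an assay on T-REx-293 cells for inhibition of potassium channel subfamily T member 1 (Homo sapiens), read by patch clamp (on this read-out higher numbers stand for weaker inhibition and lower numbers for stronger inhibition), compound 1 gives 977 nM. Compound 2 sits at the limit of > 30000 nM in this assay, at which 1 of the 2 values shown sits, which is a limit of the assay and not a number. Compound 3 `C[C@H](NC(=O)c1cc(C(F)(F)F)nn1C)c1nc(-c2ccnc(C(F)(F)F)c2)no1` differs from compound 2 in one place: 2-(trifluoromethyl)pyridin-4-yl in place of pyridin-2-yl on an aromatic carbon. For the measured compounds named here, no measured pair shows the effect of such a change, so the expectation rests on compound 1 and compound 2 alone. A step toward lower numbers is expected, an at least 7.5-fold lower number from compound 2 to compound 3 (0.87 log units; beyond the scatter), though the result could again stop at the limit. Compound 3 is estimated at 4000 nM, with a range from 600 nM to 30000 nM.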

Compound 3, half-maximal inhibitory concentration: 40 nM
For compound 3 the middle estimate is 100-fold (2.00 log units) above the measured one; measured number outside the range, below it.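

In this assay, the group on this aromatic carbon of the five-membered ring proves decisive: 2-(trifluoromethyl)pyridin-4-yl in place of pyridin-2-yl gives an at least 750-fold lower number from compound 2 to compound 3 (2.87 log units; beyond the scatter). A pyridine at this position can therefore carry strong inhibition, with compound 3 at 40 nM. Compound 2 stands at a limit of the assay and not at a number: the limit of > 30000 nM in this assay, at which 1 of the 3 values shown sits.

The change joins two differences, the pyridine's point of attachment and the added trifluoromethyl, and the compounds shown do not separate them. On these data alone, whether unsubstituted pyridin-4-yl, or a nitrile or methoxy group in place of trifluoromethyl, would keep this level remains open.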